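A few compounds are considered here, and "the series" means these few. Any claim that something is new, unique, unknown or untested is made for them only; others in the source may bear on it.

Measured in an ADME assay on microsomes from liver (Homo sapiens) for metabolic stability, read by LC-MS, using NADPH, with stated times of 5 min and 30 min, tested at 1 uM; on this read-out lower numbers stand for slow clearance and higher numbers for fast clearance:
- Compound 1 `Cn1cc(-c2cnc(NCc3c(F)ccc4c3CCO4)c3cn[nH]c(=O)c23)cn1`: 21 mL.min-1.g-1
- Compound 2 `Cc1ncccc1-c1cnc(NCc2c(F)ccc3c2CCO3)c2nn(CC#N)c(=O)n12`: 151 mL.min-1.g-1
- Compound 3 `Cc1nc(CO)ccc1-c1cnc(NCc2c(F)ccc3c2CCO3)c2cn[nH]c(=O)c12`: 11 mL.min-1.g-1

Compound 2 has the highest number of the three, beyond the scatter of the other two. Compound 4 `Cc1ncccc1-c1cnc(NCc2c(F)ccc3c2CCO3)c2n[nH]c(=O)n12` differs from compound 2 in one place: hydrogen in place of cyanomethyl on an aromatic nitrogen. Within the data shown here, no measured step makes this swap. The only one, a 1.9-fold lower number from compound 1 to compound 3 (0.28 log units; within the scatter), concerns another group. The closest evidence is indirect: on a different core, hydrogen also sits on an aromatic nitrogen in compound 1 at 21 mL.min-1.g-1 and compound 3 at 11 mL.min-1.g-1. A lower number is therefore expected, as an estimated step of a 3.8-fold lower number from compound 2 to compound 4 (0.58 log units; beyond the scatter). In this assay the estimate for compound 4 is 40 mL.min-1.g-1, expected within 15 mL.min-1.g-1 to 100 mL.min-1.g-1.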

Compound 4, intrinsic clearance in microsomes in the Homo sapiens assay: 8 mL.min-1.g-1
Compound 4: middle estimate off by 5.0-fold (0.70 log units), on the high side, outside the stated range (below it).
By their numbers in the Homo sapiens assay, from the lowest: compounds 4, 3 and 1 (each within the scatter of the next, the first and the last beyond it); then compound 2.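

Among these compounds, this is the first step that touches this aromatic nitrogen, and it shows that the position matters strongly: in the Homo sapiens assay hydrogen in place of cyanomethyl gives a 19-fold lower number from compound 2 to compound 4 (1.28 log units; beyond the scatter) with compound 2 at 151 mL.min-1.g-1 and compound 4 at 8 mL.min-1.g-1 on the shared core. Among the compounds shown here, the only earlier step concerned another group and stayed within the scatter. In a physicochemical assay for lipophilicity, using the shake flask method, in phosphate buffer, measured as octanol-water partition, with a stated time of 30 min, at pH 7.4 (a lower number here means a more polar compound, a higher number a more lipophilic compound), the same swap gives a number 0.30 log units higher from compound 2 to compound 4 (within the scatter) with compound 2 at 2.2 and compound 4 at 2.5 so the large change in clearance comes with no change beyond the scatter on that read-out.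

On these data alone, whether a methyl group or a longer chain ending in a carboxylic acid on this nitrogen would fall nearer compound 2 or compound 4 stays open. Nothing available accounts for the size of this step.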